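Adding a Nitro Group to a Potent Serotonin Receptor Ligand

A few compounds are considered here, and "the series" means these few. Any claim that something is new, unique, unknown or untested is made for them only; others in the source may bear on it.

Compound 1 `CCCCN1CCC(COC(=O)c2ccc(N)c3c2OCCO3)CC1` is the strongest binder among the three compounds measured here. In an assay on HEK293 cells for displacement of a labelled ligand from 5-hydroxytryptamine receptor 4 (Homo sapiens) (on this read-out higher numbers stand for weaker inhibition and lower numbers for stronger inhibition), compound 1 gives 1.4 nM, whereas compound 2 `CCCCN1CCC(COC(=O)c2ccc(NC)c3c2OCCO3)CC1` gives 9.1 nM and compound 3 `CCCN1CCC(COC(=O)c2ccc(N)c(OC)c2)CC1` gives 17 nM. Compound 4 `CCCCN1CCC(COC(=O)c2cc([N+](=O)[O-])c(N)c3c2OCCO3)CC1` keeps the core of compound 1 and differs in one place: nitro in place of hydrogen on an aromatic carbon. Within the data shown here, no measured pair shows this exact change, so the only guide is the step of a 6.5-fold higher number from compound 1 to compound 2 (0.81 log units; beyond the scatter), in which altering the amino group itself cost binding modestly. A modest loss is expected, roughly a 2.5-fold higher number from compound 1 to compound 4 (0.40 log units; beyond the scatter). Compound 4 is therefore estimated at 3.5 nM, within a range from 0.8 nM to 16 nM.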

Compound 4, inhibition constant: 7.8 nM
Beside the measured number, compound 4's estimate is 2.2-fold (0.35 log units) below it, and the stated range covers the measured number.
By their numbers in this assay, from the lowest: compound 1; then compounds 4, 2 and 3 (each within the scatter of the next, the first and the last beyond it).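

This aromatic carbon, ortho to the amino group, accepts a nitro group with only a modest loss: in this assay the change gives a 5.6-fold higher number from compound 1 to compound 4 (0.75 log units; beyond the scatter). Binding therefore responds to a change on the ring carbon as well as to a change on the amino nitrogen, yet it survives the addition of a group of 3 heavy atoms. Nothing available here explains the size of this loss.

On these data alone, whether chlorine, a methyl group or a nitrile on this carbon would stay closer to compound 1 remains open. So does whether nitro would cost the same alongside the methylamino group of compound 2.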